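Cyclopropane trimethoxyphenyl anilides: configuration step to compound 4

The source may report more compounds than this note shows. Statements on the series, on what has been measured and on what is new or still open speak of the compounds shown alone.

Measured so far in a functional assay on HeLa cells (Homo sapiens) for cytotoxicity, read by MTT assay, with a stated time of 48 h; on this read-out higher numbers stand for weaker inhibition and lower numbers for stronger inhibition:
- compound 1, `CCOC(=O)[C@@]1(C(=O)Nc2ccccc2Cl)C[C@H]1c1cc(OC)c(OC)c(OC)c1`, gives 14400 nM
- compound 2, `COc1cc([C@@H]2C[C@@]2(CO)C(=O)Nc2ccccc2Cl)cc(OC)c1OC`, gives 13300 nM
- compound 3, `CCOC(=O)[C@@]1(C(=O)Nc2ccccc2)C[C@H]1c1cc(OC)c(OC)c(OC)c1`, gives a limit of the assay, > 100000 nM

Compound 1 sits at the highest of the two numbers read in this assay; its nearest neighbour is compound 2, and a 1.1-fold lower number from compound 1 to compound 2 (0.03 log units; within the scatter). Going by the values given here, the only clearly sized step starting from compound 1 is an at least 6.9-fold higher number from compound 1 to compound 3 (0.84 log units; beyond the scatter); for compound 3 this rests on (the limit of > 100000 nM in this assay, at which 1 of the 3 values shown sits), so the true size of that step is open upward.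

Compound 4, `CCOC(=O)[C@@]1(C(=O)Nc2ccccc2Cl)C[C@@H]1c1cc(OC)c(OC)c(OC)c1`, is not yet measured. Against compound 1 the change is the two compounds have the same atoms and bonds and differ only in configuration as drawn: 1 of 2 stereo elements differ; a stereocentre at a saturated ring carbon is drawn S in compound 1 and R in compound 4. Neither measured step bears on this change: the step to compound 2 alters a substituent on the saturated ring and the step to compound 3 alters the aromatic ring, while the ring atoms and all groups stay the same here. There is therefore no measured precedent for a configuration change in this series, and the direction cannot be read from the numbers shown. Compound 4 is estimated in this assay at 30000 nM, within 8000 nM to 120000 nM, which corresponds to an expected step of a 2.1-fold higher number from compound 1 to compound 4 (0.32 log units; beyond the scatter). Among the compounds with values here, the range is kept wide because the only anchor is compound 1 with 14400 nM.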

Compound 4, half-maximal inhibitory concentration: > 100000 nM
Compound 4 was reported as a limit; the forecaster's own chance of this, stated with the estimate: 30%; middle value at least 3.3-fold (0.52 log units) away from the limit.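

In this assay compound 4 gives > 100000 nM, which is a limit of the assay and not a number. Going by these compounds alone, this is the first step with no change of group, and it shows that the activity of compound 1 depends on how the saturated ring carbon is drawn, S rather than R, with an at least 6.9-fold higher number from compound 1 to compound 4 (0.84 log units; beyond the scatter), a size that stays open upward: the limit of > 100000 nM in this assay, at which 2 of the 4 values shown sit. Unlike the steps to compound 2 and compound 3, which alter a substituent, this one can be assigned to configuration alone, since nothing enters or leaves: the fact that compounds 1 and 4 differ only in the configuration as drawn.

The compounds shown leave open what the second stereo element contributes, and whether the same dependence on configuration holds when hydroxymethyl replaces ethoxycarbonyl, as in compound 2. They also leave open how far the S series tolerates other groups, such as a carboxylic acid or an amide in place of ethoxycarbonyl, or fluoro or methoxy in place of chloro on the aromatic carbon.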